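Fluoro to Methyl on a Shared Aryl Ring

A few compounds are considered here, and "the series" means these few. Any claim that something is new, unique, unknown or untested is made for them only; others in the source may bear on it.

Compound 1, `Fc1ccc(-c2cc(/C=N/c3ccccc3)on2)cc1`, gives 41200 nM in a functional assay on MDA-MB-231 cells (Homo sapiens) for inhibition, read by MTT assay, with a stated time of 24 h; a higher number here means a weaker inhibitor, a lower number a stronger inhibitor. Compound 2, `Cc1ccc(-c2cc(/C=N/c3ccccc3)on2)cc1`, gives 29400 nM in this assay. Compound 3, `CCc1cc2ccccc2nc1-c1cc(-c2ccc(F)cc2)no1`, reaches only a limit of the assay, > 100000 nM, in this assay.

Compound 4, `CCc1cc2ccccc2nc1-c1cc(-c2ccc(C)cc2)no1`, has not yet been measured in this assay. The difference between the core of compound 1 and the core of compound 3 is not broken down here. Within the first pair the change is methyl in place of fluoro on an aromatic carbon, and it gave a 1.4-fold lower number from compound 1 to compound 2 (0.15 log units; within the scatter). The change from compound 3 to compound 4 is methyl in place of fluoro on an aromatic carbon, the same change on the same kind of place. Compound 3 sits at the limit of > 100000 nM in this assay, at which 1 of the 3 values shown sits, so its own value is not a number but a limit.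

Since the measured step with this change stayed within the scatter, the expectation for compound 4 in this assay rests on compound 3 staying at its limit and on a 1.4-fold lower number from compound 1 to compound 2 (0.15 log units; within the scatter) being small. Compound 4 is therefore expected to show a number no higher from compound 3 to compound 4 (the limit leaves the size open). Compound 4 is estimated at 100000 nM, with a likely range from 40000 nM to 300000 nM, most probably reported again only as a limit.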

Compound 4, half-maximal inhibitory concentration: > 100000 nM
Compound 4: no number, only a limit (the forecaster's own chance of this, stated with the estimate: 70%); the middle value lies on the limit itself.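

No new step can be read from compound 3 to compound 4, as in this assay both reach only a limit and give no number: the limit of > 100000 nM in this assay, at which 2 of the 4 values shown sit.

The compounds shown leave open how large the change from 4-fluorophenyl to 4-methylphenyl is on the core of compound 3, and whether it resembles the change on the core of compound 1.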